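Swapping nitro for fluoro on an aromatic carbon

The source may report more compounds than this note shows. Statements on the series, on what has been measured and on what is new or still open speak of the compounds shown alone.

In a functional assay on U-87MG ATCC cells (Homo sapiens) for cytotoxicity, read by MTT assay, with a stated time of 48 h (a higher number here means a weaker inhibitor, a lower number a stronger inhibitor), compound 2 `C/C(=N/NC(=S)Nc1cccc([N+](=O)[O-])c1)c1ccccn1` gives 69 nM as the higher of two numbers, while compound 1 `CC(=NNC(=S)Nc1cccc(F)c1)c1ccccn1` gives 18 nM as the lower, a gap beyond the scatter. Compound 3 `C/C(=N/NC(=S)Nc1cccc(F)c1)c1ccccn1` has fluoro in place of nitro on an aromatic carbon. Compound 1 also carries fluoro there, and its 18 nM is the basis for the expectation. The expected change is a 3.1-fold lower number from compound 2 to compound 3 (0.50 log units; beyond the scatter) toward a stronger inhibitor, beyond the scatter in this assay and not within it. Compound 3 is estimated at 22 nM with an expected range from 10 nM to 50 nM in this assay when measured.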

Compound 3, half-maximal inhibitory concentration: 18 nM
For compound 3 the middle estimate is 1.2-fold (0.09 log units) above the measured one; the measured number falls inside the stated range.
By their numbers in this assay, from the lowest: compounds 1 and 3 (each within the scatter of the next); then compound 2.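

With the double bond now drawn the same way in both compounds, fluoro in place of nitro on the aromatic carbon stands as a single change: in this assay it gives a 3.8-fold lower number from compound 2 to compound 3 (0.58 log units; beyond the scatter). The comparison with compound 1 gives no change at the digits printed from compound 1 to compound 3 (within the scatter), so a defined configuration at the double bond adds no visible difference to the number, and only the drawing separates the pair: the fact that one of compounds 1 and 3 is drawn with a defined configuration and the other without, at the place where they differ

The compounds shown leave open how an amine or a chloro group on that aromatic carbon would compare. They also leave open whether the opposite configuration at the double bond would give a different number.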